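A few compounds are considered here, and "the series" means these few. Any claim that something is new, unique, unknown or untested is made for them only; others in the source may bear on it.

Compounds measured in a functional assay on K562 cells (Homo sapiens) for cytotoxicity, read by MTT assay, with a stated time of 48 h; on this read-out lower numbers stand for stronger inhibition and higher numbers for weaker inhibition:

Compound 1, `Cc1ccc(CN2CCN(C(=O)CN[C@H]3CCN(S(=O)(=O)Cc4ccccc4)C3)CC2)cc1`, gives 8200 nM.
Compound 2, `O=C(CN[C@H]1CCN(S(=O)(=O)Cc2ccccc2)C1)N1CCN(Cc2ccccc2Cl)CC1`, gives 9000 nM.
Compound 3, `O=C(CN[C@H]1CCN(S(=O)(=O)Cc2ccccc2)C1)N1CCN(Cc2cccc(F)c2)CC1`, gives 13200 nM.

The three compounds share one core and differ only in the aromatic group on a saturated chain carbon bound to an amine nitrogen in a ring. Compound 2 holds the second highest of the three numbers; its nearest neighbour is compound 1, with a 1.1-fold higher number from compound 1 to compound 2 (0.04 log units; within the scatter), and its furthest is compound 3, with a 1.5-fold higher number from compound 2 to compound 3 (0.17 log units; within the scatter). The step of a 1.6-fold higher number from compound 1 to compound 3 (0.21 log units; within the scatter) is likewise within the scatter, so on these numbers nothing separates the three.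

Compound 4, `O=C(CN[C@H]1CCN(S(=O)(=O)Cc2ccccc2)C1)N1CCN(Cc2ccc(F)cc2)CC1`, has not yet been measured in this assay. Its change from compound 2 is 4-fluorophenyl in place of 2-chlorophenyl on a saturated chain carbon bound to an amine nitrogen in a ring. Among the measured compounds shown here, the steps that bear on it are the two that change the aromatic group on compound 2, and both stayed within the scatter. The author therefore expects no step beyond the scatter in this assay, that is a 1.1-fold higher number from compound 2 to compound 4 (0.05 log units; within the scatter). For compound 4 the estimate is 10000 nM, with a range of 5000 nM to 20000 nM.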

Compound 4, half-maximal inhibitory concentration: 14300 nM
The estimate for compound 4 lay 1.4-fold (0.16 log units) below the measured number; the measured number falls inside the stated range.
By their numbers in this assay, from the lowest: compounds 1, 2, 3 and 4 (each within the scatter of the next).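

In this assay, 4-fluorophenyl at this place, on a saturated chain carbon bound to an amine nitrogen in a ring, extends the flat picture: in place of 2-chlorophenyl it gives a 1.6-fold higher number from compound 2 to compound 4 (0.20 log units; within the scatter). Shifting the fluoro group from 3-fluorophenyl to 4-fluorophenyl gives a 1.1-fold higher number from compound 3 to compound 4 (0.03 log units; within the scatter), so these two fluorophenyl groups are not told apart, and fluoro in place of methyl on an aromatic carbon gives a 1.7-fold higher number from compound 1 to compound 4 (0.24 log units; within the scatter), the largest of the new steps yet still within the scatter. Across these four compounds, then, neither the substituent nor its printed place on the aromatic ring separates the numbers.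

No evidence is available that would account for these numbers. Going by these compounds, whether any group here can produce a step beyond the scatter remains open, for instance a carboxylic acid or an amine on the phenyl ring, or a longer chain in place of the single saturated carbon.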